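Branching the alkoxy chain in a bile acid receptor series

This account rests on a few compounds, and the source may have more. Where it says the series, first, only, none or still open, it means among the compounds named here.

Measured compounds:
compound 1, `CCCCOc1cccc(C(=O)Nc2cccc(C(=O)O)c2)c1`: 3150 nM
compound 2, `CCCCCOc1cccc(C(=O)Nc2cccc(C(=O)O)c2)c1`: 2540 nM

Of the compounds shown here, two of the shared core have been tested in an assay on isolated protein for agonist activity at Bile acid receptor (Homo sapiens), read by TR-FRET, with a stated time of 3 h, in the absence of a further agent; a higher number here means that more compound is needed for the effect, a lower number that less compound is needed. Compound 1 carries a butoxy group and gives 3150 nM in this assay. Compound 2 carries a pentoxy group and gives 2540 nM in this assay. For the measured compounds named here, the only measured step, a 1.2-fold lower number from compound 1 to compound 2 (0.09 log units; within the scatter), is within the scatter, so compound 2 and compound 1 cannot be told apart on these numbers; compound 2 simply sits beside compound 1 as the other of the pair.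

The next compound is compound 3, `CC(C)COc1cccc(C(=O)Nc2cccc(C(=O)O)c2)c1`. It differs from compound 2 by isopropyl in place of butyl on a saturated chain carbon bound to an oxygen on an aromatic ring, that is, pentyloxy to isobutoxy. Going by the values given here, no measured step involves a branched chain, so the only guide is that lengthening the chain, from compound 1 to compound 2, moved the number little. Shortening and branching it is therefore expected to produce at most a small step: the estimated step from compound 2 to compound 3 is a 1.4-fold higher number from compound 2 to compound 3 (0.14 log units; within the scatter), with no direction claimed beyond the scatter. Compound 3 is expected to give about 3500 nM in this assay, within a range from 1500 nM to 8000 nM.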

Compound 3, half-maximal effective concentration: 1130 nM
Compound 3: the middle estimate sits 3.1-fold (0.49 log units) above what was measured; the measured number lies below the stated range.
By their numbers in this assay, from the lowest: compound 3; then compounds 2 and 1 (each within the scatter of the next).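

At the saturated chain carbon bound to an oxygen on an aromatic ring, the isobutoxy chain of compound 3 separates from both straight chains in this assay, with a 2.2-fold lower number from compound 2 to compound 3 (0.35 log units; beyond the scatter) and a 2.8-fold lower number from compound 1 to compound 3 (0.45 log units; beyond the scatter). Compounds 1 and 2 could not be told apart, so the pair gave no sign that this position responds to a change, whereas isopropyl in place of butyl or propyl gives a modest but readable step. Nothing available explains why the branched chain gives the lower number.

The compounds shown leave open whether this step belongs to branching in general or to the isobutoxy chain alone, as they hold a single branched chain, and a sec-butoxy, neopentyloxy or cyclopropylmethoxy group would bear on that question. They also leave open whether a longer branched chain such as isopentyloxy would lower the number further, and how a hydroxyl group or an amine on the chain would change it.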